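A chloro group added to compound 3

A few compounds are considered here, and "the series" means these few. Any claim that something is new, unique, unknown or untested is made for them only; others in the source may bear on it.

In a functional assay on MCF7 cells (Homo sapiens) for antiproliferative activity, read by MTT assay, with a stated time of 48 h (on this read-out higher numbers stand for weaker inhibition and lower numbers for stronger inhibition), compound 1 (`O=[N+]([O-])c1cccc(-c2nn(-c3ccccc3)cc2C(Nc2nc3ccccc3s2)c2c(O)ccc3ccccc23)c1`) gives 43900 nM, compound 2 (`O=[N+]([O-])c1ccc(-c2nn(-c3ccccc3)cc2C(Nc2nc3ccccc3s2)c2c(O)ccc3ccccc23)cc1`) gives 14700 nM and compound 3 (`Oc1ccc2ccccc2c1C(Nc1nc2ccccc2s1)c1cn(-c2ccccc2)nc1-c1ccc(I)cc1`) gives 18900 nM. Set against the other two, the numbers show a 1.3-fold higher number from compound 2 to compound 3 (0.11 log units; within the scatter), and a 2.3-fold lower number from compound 1 to compound 3 (0.37 log units; beyond the scatter). Compound 3 therefore cannot be separated from compound 2, while it clearly differs from compound 1.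

Compound 4 (`Oc1ccc2ccccc2c1C(Nc1nc2ccc(Cl)cc2s1)c1cn(-c2ccccc2)nc1-c1ccc(I)cc1`) keeps everything in compound 3 except that the 1,3-benzothiazol-2-yl group becomes 6-chloro-1,3-benzothiazol-2-yl: chloro in place of hydrogen on an aromatic carbon. This is chloro in place of hydrogen on an aromatic carbon.

Within the data shown here, none of the measured steps touches this group, since all of them alter the aryl substituent, so no direct precedent exists and the direction remains open. They do show how far single changes have moved this series, reaching a 3.0-fold lower number from compound 1 to compound 2 (0.48 log units; beyond the scatter). On that basis, only a small change is expected, and the estimated outcome is a 1.4-fold lower number from compound 3 to compound 4 (0.13 log units; within the scatter). Compound 4 is estimated at 14000 nM, with an expected range from 5500 nM to 35000 nM.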

Compound 4, half-maximal inhibitory concentration: 65000 nM
Beside the measured number, compound 4's estimate is 4.6-fold (0.67 log units) below it; the whole stated range lies below it.
By their numbers in this assay, from the lowest: compounds 2 and 3 (each within the scatter of the next); then compounds 1 and 4 (each within the scatter of the next).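

Compound 4 is the only change shown on the 1,3-benzothiazol-2-yl group rather than on the aryl substituent, and in this assay chloro in place of hydrogen there gives a 3.4-fold higher number from compound 3 to compound 4 (0.54 log units; beyond the scatter), towards weaker inhibition. This position therefore responds to a single added chlorine, with a step of similar size to the largest among the aryl changes, a 3.0-fold lower number from compound 1 to compound 2 (0.48 log units; beyond the scatter). Nothing available explains the direction of this step.

Only hydrogen and chloro are shown at this place, so it remains open whether the weaker inhibition is particular to chloro or would also follow from a fluoro, a methoxy or an amine there. As far as these compounds go, it is equally open whether the same step would appear with the 4-nitrophenyl of compound 2 in place of the 4-iodophenyl.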